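Ethyl to methoxy on a shared naphthalene-type core

The source may report more compounds than this note shows. Statements on the series, on what has been measured and on what is new or still open speak of the compounds shown alone.

The series rests on a shared core carrying a substituted furan with a methyl group and a carboxylic acid or ester. Compound 1, `CCc1cccc2c(OC)c(-c3occ(C)c3C(=O)OC)ccc12`, bears an ethyl group on the aromatic ring and a methyl ester together with a methoxy group. In a functional assay on SK-BR-3 cells (Homo sapiens) for cytotoxicity, read by sulforhodamine B assay, with a stated time of 72 h (on this read-out higher numbers stand for an effect only at larger amounts of compound and lower numbers for an effect already at smaller amounts), compound 1 gives 1.2 ug/mL. Compound 2, `CCc1cccc2c(O)c(-c3occ(C)c3C(=O)O)ccc12`, keeps the ethyl group but carries the free acid and the free hydroxyl; in this assay compound 2 gives 1 ug/mL. The two numbers lie within the usual scatter of each other, so compound 2 cannot be told apart from compound 1 on this read-out.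

Compound 3, `COc1cccc2c(O)c(-c3occ(C)c3C(=O)O)ccc12`, is not yet measured. It differs from compound 2 in one place: methoxy in place of ethyl on an aromatic carbon. Among the compounds with values here, no measured pair shows what this particular exchange does, so the expectation rests only on the closeness of the two values seen so far. Compound 3 is expected to stay near compound 2, with a step of a 1.5-fold higher number from compound 2 to compound 3 (0.18 log units; within the scatter) that need not exceed the scatter. Compound 3 is therefore estimated at 1.5 ug/mL, with a range from 0.6 ug/mL to 4 ug/mL.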

Compound 3, concentration for half-maximal effect: 3.5 ug/mL
For compound 3 the middle estimate is 2.3-fold (0.37 log units) below the measured one, and the stated range covers the measured number.
By their numbers in this assay, from the lowest: compounds 2 and 1 (each within the scatter of the next); then compound 3.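

Methoxy in place of ethyl on an aromatic carbon is the first exchange in this series with a readable outcome: in this assay it gives a 3.5-fold higher number from compound 2 to compound 3 (0.54 log units; beyond the scatter), so this position is not indifferent to the group it carries. The exchange keeps the number of heavy atoms and adds neither a ring nor a net charge; what enters is an oxygen in place of a carbon, and with it a hydrogen-bond acceptor, and even a change this small in atoms shows on this read-out, whereas compound 1 and compound 2 could not be told apart. No measurement at hand bears on why the step arises.

As far as these compounds go, whether an amine, a chloro group or a longer chain such as propyl on this aromatic carbon would stay near compound 2 or move as compound 3 does remains open. From the compounds shown here alone, it is also open whether the same exchange would have a similar effect in the methyl ester and methoxy form of compound 1, as it is seen here only with the free acid and the free hydroxyl.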